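Swapping Piperidinyl for Cyclopropyl on an Indane Urea

The source may hold more compounds than are shown below. What is called first, only, known or untested is meant among the compounds shown, and "the series" means these compounds.

Of the compounds shown here, three sharing one urea core have been measured in an assay on isolated protein for inhibition of transient receptor potential cation channel subfamily V member 1 (Homo sapiens), read by calcium flux; a higher number here means a weaker inhibitor, a lower number a stronger inhibitor. Compound 1 `O=C(Nc1cccc2[nH]ncc12)NC1CCc2c1cccc2N1CCCCC1` gives 10 nM, the lowest of the three numbers. Compound 3 `Cc1ccc2c(c1)CCC2NC(=O)Nc1cccc2[nH]ncc12`, which carries a methyl group, gives 11 nM, a result within the scatter of compound 1, so the two cannot be ranked against each other. Compound 2 `O=C(Nc1cccc2[nH]ncc12)NC1CCc2cccnc21` gives 1350 nM, a number far beyond the scatter from compound 1, and it stands furthest from it.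

Compound 4 `O=C(Nc1cccc2[nH]ncc12)NC1CCc2c(C3CC3)cccc21` has not yet been measured. It differs from compound 1 in one place: cyclopropyl in place of piperidin-1-yl on an aromatic carbon. A six-membered ring holding a nitrogen is thus exchanged for a small ring of three carbons at the same aromatic carbon.

Among the measured compounds shown here, no measured pair shows this exact exchange, so the size of the step can only be estimated. Since compound 1 at 10 nM and compound 3 at 11 nM both sit at the low end despite carrying quite different groups, the urea core itself seems to carry much of the potency. A small loss is expected, but not beyond the scatter: the step from compound 1 to compound 4 is estimated at a 2.0-fold higher number from compound 1 to compound 4 (0.30 log units; within the scatter). Compound 4 is therefore expected to give 20 nM, within a range from 6 nM to 70 nM.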

Compound 4, half-maximal inhibitory concentration: 5 nM
For compound 4 the middle estimate is 4.0-fold (0.60 log units) above the measured one; measured number outside the range, below it.
By their numbers in this assay, from the lowest: compounds 4, 1 and 3 (each within the scatter of the next, the first and the last beyond it); then compound 2.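

In this assay, the step from the piperidin-1-yl group to cyclopropyl is a 2.0-fold lower number from compound 1 to compound 4 (0.30 log units; within the scatter), so this single exchange cannot separate the two compounds. This aromatic carbon of the core therefore accepts two quite different rings with no change beyond the usual scatter: one six-membered with 6 heavy atoms, including a nitrogen that counts as a hydrogen-bond acceptor, and the other three-membered with 3 heavy atoms, all carbon. For this pair, then, neither that nitrogen, that acceptor nor the larger ring is required for a low number, although no measurement on these compounds explains why the two rings perform alike.

The compounds shown cover only these two rings at this position, so it remains open whether a carboxylic acid, a primary amine or a longer chain such as n-butyl on the same aromatic carbon would also keep the number low. Going by these compounds, it is equally open whether a hydrogen atom alone would do so, which would show whether any ring is needed at this carbon at all.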